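Alkylation of the phenolic oxygen on the shared core

This account rests on a few compounds, and the source may have more. Where it says the series, first, only, none or still open, it means among the compounds named here.

Compound 2 `COc1cc(C2C(C#N)=C(N)Oc3cc(O)ccc32)cc(Br)c1OC` gives 130000000 nM in a functional assay on T47D cells (Homo sapiens) for activation (a lower number here means that less compound is needed, a higher number that more compound is needed for the effect), the higher of the two values available. Among the compounds with values here, its only measured neighbour, compound 1 `CCOc1ccc2c(c1)OC(N)=C(C#N)C2c1cc(Br)c(OC)c(OC)c1`, gives 64000000 nM in this assay; the two are joined by the single measured step of a 2.0-fold higher number from compound 1 to compound 2 (0.31 log units; beyond the scatter), in which the ethyl on the aromatic oxygen is replaced by hydrogen.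

Compound 3 `COc1ccc2c(c1)OC(N)=C(C#N)C2c1cc(Br)c(OC)c(OC)c1` awaits measurement. It differs from compound 2 by methyl in place of hydrogen on an oxygen on an aromatic ring. Within the data shown here, the one step that bears on this change is a 2.0-fold higher number from compound 1 to compound 2 (0.31 log units; beyond the scatter), which runs in the opposite direction (ethyl removed from the same oxygen) and raised the number beyond the scatter. Putting a methyl back on that oxygen is expected to reverse this, giving a lower number, most likely of about the same size as that step, although the alkyl group is now one carbon shorter than in compound 1, so compound 3 need not land exactly on compound 1.

Compound 3 is therefore expected to give 70000000 nM in this assay, with a range from 30000000 nM to 160000000 nM. The expected step of a 1.9-fold lower number from compound 2 to compound 3 (0.27 log units; within the scatter) would roughly mirror the measured one.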

Compound 3, half-maximal effective concentration: 17000000 nM
Compound 3: middle estimate off by 4.1-fold (0.61 log units), on the high side, outside the stated range (below it).
By their numbers in this assay, from the lowest: compound 3; then compound 1; then compound 2.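

Position and change: on the oxygen on an aromatic ring, methyl in place of hydrogen gives a 7.6-fold lower number from compound 2 to compound 3 (0.88 log units; beyond the scatter) in this assay, so the second alkyl group on this oxygen also lowers the number relative to the free hydroxy compound. The alkyl groups are not interchangeable here: going from ethyl to methyl on the same oxygen gives a 3.8-fold lower number from compound 1 to compound 3 (0.58 log units; beyond the scatter), a difference beyond the scatter that the earlier pair could not reveal. The order from the lowest number is now methyl, ethyl, hydrogen, so the number does not move steadily with the size of the group across these three compounds, and compound 3 sits lowest with steps to both others printed beyond the scatter.
Nothing available explains this order of the three compounds.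

Open points: with only hydrogen, methyl and ethyl on this oxygen, it remains unclear whether a longer chain such as propyl, or a chain ending in an amine, would continue the rise seen from methyl to ethyl. On these data alone, all three compounds also keep the same bromo and dimethoxy aryl part, so whether the methyl preference holds with another group on that ring remains unknown.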